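A Longer Chain on the Shared Core: Compound 3

The source may report more compounds than this note shows. Statements on the series, on what has been measured and on what is new or still open speak of the compounds shown alone.

Of the compounds shown here, two have so far been tested in a functional assay for agonist activity at 5-hydroxytryptamine receptor 4 (Cavia porcellus); a higher number here means a larger maximal response, a lower number a smaller maximal response. Compound 1, `CC(C)n1c(=O)n(C(=O)NCCN2CCN(C)CC2)c2cc(F)ccc21`, gives 0.67 in this assay. Compound 2, `CCn1c(=O)n(C(=O)NCCN2CCN(C)CC2)c2ccccc21`, gives only a limit in this assay: its value is recorded as < 0.3, a limit of the assay rather than a number (the limit of < 0.3 in this assay, at which 1 of the 2 values shown sits). Compound 1 and compound 2 differ in two places at once, so their two values show only that one reaches a clear response while the other does not rise above the limit.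

Compound 3, `CCCCn1c(=O)n(C(=O)NCCN2CCN(C)CC2)c2ccccc21`, has not yet been measured. It differs from compound 2 by ethyl in place of hydrogen on a saturated chain carbon, two bonds along the chain from an aromatic nitrogen. Going by the values given here, no measured pair in this set shows the effect of such a change on its own, so the size and direction of the step can only be judged roughly. The expectation is a modest rise, estimated as a number at least 0.10 higher from compound 2 to compound 3 (that floor lies within the scatter), though a value at the limit again would not be surprising. Compound 3 is therefore expected to give about 0.4 in this assay, within a range from 0.25 to 0.65.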

Compound 3, intrinsic activity: the largest response reached, as a fraction of the reference agonist's: < 0.3
Compound 3 gave a limit, no number; the forecaster's own chance of this, stated with the estimate: 35%; middle value at least 0.10 from the limit.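

In this assay compound 3 gives < 0.3 as a limit of the assay and not a number. Going by these compounds alone, compound 2 also stands only at a limit, and no step between compound 2 and compound 3 can be read: the limit of < 0.3 in this assay, at which 2 of the 3 values shown sit. Still open, from the compounds shown here alone, is whether ethyl in place of hydrogen at this place changes the maximal response at all.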